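Swapping bromo for hydroxy on the anilide ring

A few compounds are considered here, and "the series" means these few. Any claim that something is new, unique, unknown or untested is made for them only; others in the source may bear on it.

Within the data shown here, compound 1 `O=C(CSC(=S)N[C@H]1CCOC1=O)Nc1ccc(Br)cc1` is the only member of this set with a measured number in a functional assay on SMMC-7721 cells (Homo sapiens) for cytotoxicity, read by MTT assay, with a stated time of 72 h; on this read-out lower numbers stand for stronger inhibition and higher numbers for weaker inhibition: compound 1 gives 28300 nM. Compound 2 `Cc1cccc(NC(=O)CSC(=S)N[C@H]2CCOC2=O)c1` reaches only a limit, > 128000 nM. Compound 3 `O=C(CSC(=S)N[C@H]1CCOC1=O)Nc1ccc(F)cc1` likewise stops at a limit, > 128000 nM. Both sit at the limit of > 128000 nM in this assay, at which 2 of the 3 values shown sit. Compound 4 `O=C(CSC(=S)N[C@H]1CCOC1=O)Nc1ccc(O)cc1` differs from compound 1 by hydroxy in place of bromo on an aromatic carbon. Among the measured compounds shown here, two measured steps bear on this change: an at least 4.5-fold higher number from compound 1 to compound 2 (0.65 log units; beyond the scatter) and an at least 4.5-fold higher number from compound 1 to compound 3 (0.65 log units; beyond the scatter), each beyond the scatter and each toward weaker inhibition. Every change away from bromo seen so far has weakened inhibition, so a weakening step of similar size is expected here, namely a 3.9-fold higher number from compound 1 to compound 4 (0.59 log units; beyond the scatter). Compound 4 is therefore estimated at 110000 nM, with a range from 30000 nM to 400000 nM, and may well be reported only as a limit.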

Compound 4, half-maximal inhibitory concentration: > 128000 nM
Compound 4 was reported as a limit; the forecaster's own chance of this, stated with the estimate: 55%; at least 1.1-fold (0.06 log units) between middle value and limit.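

Replacing bromo with hydroxy on this aromatic carbon gives, in this assay, an at least 4.5-fold higher number from compound 1 to compound 4 (0.65 log units; beyond the scatter), so hydroxy is a second group at this position, after fluoro, that does not keep the measured inhibition of compound 1. Compound 1 remains the only compound here with an actual number, and the others all stop at the same limit: the limit of > 128000 nM in this assay, at which 3 of the 4 values shown sit.

The steps among compound 2, compound 3 and compound 4 cannot be read, as both ends of each are limits. Going by these compounds, whether bromo alone keeps a measurable number stays open: chloro, iodo, methoxy or an amine at this position would test that.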